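The source may hold more compounds than are shown below. What is called first, only, known or untested is meant among the compounds shown, and "the series" means these compounds.

Working notes on the series. For the measured compounds named here, compound 2 `CCC(CO)Nc1nc(NCc2ccccc2)c2nc(N)n(C(C)C)c2n1` stands at the highest of the two numbers so far in a functional assay on MCF7 cells (Homo sapiens) for cytotoxicity (on this read-out higher numbers stand for weaker inhibition and lower numbers for stronger inhibition), where compound 2 gives 60000 nM. Going by the values given here, compound 1 `CCC(CO)Nc1nc(NCc2cccc(O)c2)c2nc(Cl)n(C(C)C)c2n1` differs from compound 2 in more than one place, so no single step connects the two; compound 1 gives 27000 nM in this assay, a lower number than compound 2, and the gap between them lies beyond the usual scatter.

Compound 3 `CCC(CO)Nc1nc(NCc2ccccc2)c2nc([N+](=O)[O-])n(C(C)C)c2n1` is not yet measured. It differs from compound 2 in one place: nitro in place of amino on an aromatic carbon. Among the compounds with values here, no measured pair shows this change, so nothing in the present numbers tells its size or direction. For compound 3 the expected step is a 1.5-fold lower number from compound 2 to compound 3 (0.18 log units; within the scatter), small and uncertain, with no firm expectation of a change beyond the scatter. Compound 3 is estimated at 40000 nM in this assay, within a range from 12000 nM to 130000 nM.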

Compound 3, half-maximal inhibitory concentration: 117000 nM
Compound 3: middle estimate off by 2.9-fold (0.47 log units), on the low side; measured number inside the range.
By their numbers in this assay, from the lowest: compound 1; then compounds 2 and 3 (each within the scatter of the next).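

For the compounds shown here, on an aromatic carbon between two ring nitrogen atoms, next to the ring atom that bears an isopropyl group, the first single-place comparison gives a 2.0-fold higher number from compound 2 to compound 3 (0.29 log units; within the scatter) in this assay. This position therefore accepts nitro in place of amino, with three heavy atoms replacing one and no hydrogen-bond donor left there, without a change beyond the scatter on this read-out. No measurement at hand bears on why the step has this size.

Open, as far as these compounds go, is whether a different group at this position, such as a methyl, a carboxylic acid or a longer alkyl chain, would shift the number beyond the scatter. Also open, from the compounds shown here alone, is how the chlorine of compound 1 would read on the otherwise unchanged core of compound 2, as compound 1 differs from it in a second place.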